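Pyridin-4-yl in place of 4-fluorophenyl: working notes

The source may report more compounds than this note shows. Statements on the series, on what has been measured and on what is new or still open speak of the compounds shown alone.

In a functional assay on NCI-H1299 cells (Homo sapiens) for antiproliferative activity, read by CCK-8 assay, with a stated time of 72 h (on this read-out higher numbers stand for weaker inhibition and lower numbers for stronger inhibition), compound 1 `Nc1ccccc1NC(=O)c1ccc(CSC(=S)N2CCN(c3ccccc3)CC2)cc1` gives 610 nM, compound 2 `Nc1ccccc1NC(=O)c1ccc(CSC(=S)N2CCN(c3ccc(F)cc3)CC2)cc1` gives 980 nM and compound 3 `CC1CCCCN1C(=S)SCc1ccc(C(=O)Nc2ccccc2N)cc1` gives 1300 nM. Compound 2 therefore lies within the scatter of both compound 1 and compound 3, so no order can be drawn around it.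

Compound 4 `Nc1ccccc1NC(=O)c1ccc(CSC(=S)N2CCN(c3ccncc3)CC2)cc1` has not yet been measured. The structural change is pyridin-4-yl in place of 4-fluorophenyl on an amine nitrogen in a ring.

Among the compounds with values here, one measured step bears on this aromatic group: a 1.6-fold higher number from compound 1 to compound 2 (0.21 log units; within the scatter), fluoro in place of hydrogen, which stays within the scatter. Within the data shown here, no measured step brings in an aromatic ring with a hetero atom, so the direction remains open and the range is kept wide. In this assay, no shift beyond the scatter is expected, and the estimated step is a 1.2-fold lower number from compound 2 to compound 4 (0.09 log units; within the scatter). For compound 4 the estimated value is 800 nM, with an expected range from 300 nM to 2000 nM.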

Compound 4, half-maximal inhibitory concentration: 2490 nM
Estimate against measurement, compound 4: 3.1-fold (0.49 log units) below, and the stated range ends below it.
By their numbers in this assay, from the lowest: compounds 1, 2, 3 and 4 (each within the scatter of the next, the first and the last beyond it).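

In this assay, the aromatic group on the amine nitrogen in a ring now gives steps beyond the scatter: a 2.5-fold higher number from compound 2 to compound 4 (0.40 log units; beyond the scatter), and a 4.1-fold higher number from compound 1 to compound 4 (0.61 log units; beyond the scatter). Within the data shown here, the only earlier step at this group, fluoro in place of hydrogen, stayed within the scatter, so that step did not show what is seen now: this position does respond to a change, and pyridin-4-yl goes with modestly weaker inhibition than either phenyl or 4-fluorophenyl. Nothing at hand accounts for the size or direction of these steps.

Only one aromatic ring with a hetero atom is shown, so it remains open whether pyridin-3-yl or pyridin-2-yl would follow pyridin-4-yl. Also open, on these data alone, is how a phenyl ring carrying a methoxy group or a chlorine atom would compare with phenyl.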